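The compounds below may be only part of what the source reports. "The series", "measured", "known", "first", "only" and "open" are said of these compounds alone.

Two measured compounds anchor this comparison. In a functional assay on CHO cells for inhibition of metabotropic glutamate receptor 5 (Rattus norvegicus), read by FLIPR and calcium flux (on this read-out higher numbers stand for weaker inhibition and lower numbers for stronger inhibition), compound 1 `Cc1ccc2ccc(-c3cccc(O)c3)cc2n1` gives 19000 nM, while compound 2 `CCSc1cc(C#N)cc(-c2ccc3ccc(C)nc3c2)c1` gives 72 nM, the lowest of the two numbers, a gap far beyond the scatter. Compound 3 `Cc1ccc2ccc(-c3cc(O)cc(C#N)c3)cc2n1` differs from compound 2 by hydroxy in place of ethylsulfanyl on an aromatic carbon. Among the compounds with values here, no measured pair isolates this change, but compound 1, which also carries a hydroxy group, gives 19000 nM, so a sizeable loss is expected, with the step from compound 2 to compound 3 estimated at a 21-fold higher number from compound 2 to compound 3 (1.32 log units; beyond the scatter). Compound 3 is therefore expected near 1500 nM, within a range of 300 nM to 8000 nM.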

Compound 3, half-maximal inhibitory concentration: 360 nM
The estimate for compound 3 lay 4.2-fold (0.62 log units) above the measured number; measured number inside the range.
By their numbers in this assay, from the lowest: compound 2; then compound 3; then compound 1.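

In this assay, hydroxy in place of ethylsulfanyl on this aromatic carbon gives only a modest loss, a 5.0-fold higher number from compound 2 to compound 3 (0.70 log units; beyond the scatter), so the position keeps measurable inhibition with the smaller group. With hydroxy held in place, cyano in place of hydrogen brings a large gain, a 53-fold lower number from compound 1 to compound 3 (1.72 log units; beyond the scatter). Nothing shown gives a reason for either step. Going by these compounds, whether an amine or a longer chain such as propylsulfanyl on this carbon would match compound 2 stays open. So does the size of the cyano step when ethylsulfanyl replaces hydroxy.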